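Swapping Iodo for Ethoxycarbonyl on the Ester Ring

This account rests on a few compounds, and the source may have more. Where it says the series, first, only, none or still open, it means among the compounds named here.

Three compounds share one core and differ only in the substituent on the aromatic ring of the ester. Compound 1 `Cc1ccc(C(=O)OC2(C(=O)Nc3ccc([N+](=O)[O-])cc3)CCCCC2)cc1` gives 9.8 nM in a functional assay on MCF7 cells (Homo sapiens) for inhibition, read by MTT assay, with a stated time of 72 h; a higher number here means a weaker inhibitor, a lower number a stronger inhibitor. Compound 2 `Cc1ccccc1C(=O)OC1(C(=O)Nc2ccc([N+](=O)[O-])cc2)CCCCC1` gives 516 nM, and compound 3 `O=C(OC1(C(=O)Nc2ccc([N+](=O)[O-])cc2)CCCCC1)c1ccccc1I` gives 619 nM. Compound 3 thus holds the highest number of the three, though it lies within the scatter of compound 2, as a 1.2-fold higher number from compound 2 to compound 3 (0.08 log units; within the scatter) shows; against compound 1 the gap is large, a 63-fold higher number from compound 1 to compound 3 (1.80 log units; beyond the scatter), and much like a 53-fold higher number from compound 1 to compound 2 (1.72 log units; beyond the scatter).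

Compound 4 `CCOC(=O)c1ccccc1C(=O)OC1(C(=O)Nc2ccc([N+](=O)[O-])cc2)CCCCC1` is the next step: ethoxycarbonyl in place of iodo on an aromatic carbon. For the measured compounds named here, the one measured step that bears directly on it is the exchange at that same aromatic carbon, a 1.2-fold higher number from compound 2 to compound 3 (0.08 log units; within the scatter), which stayed within the scatter. The two large steps away from compound 1 turn on where the substituent sits rather than on what it is, so they give no reason to expect a shift here. Compound 4 is therefore expected to stay close to compound 3, with a 1.0-fold lower number from compound 3 to compound 4 (0.01 log units; within the scatter) not beyond the scatter. The estimate for compound 4 in this assay is 600 nM, with a range from 200 nM to 2000 nM.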

Compound 4, half-maximal inhibitory concentration: 444 nM
The estimate for compound 4 lay 1.4-fold (0.13 log units) above the measured number; low and high end bracket the measured number.
By their numbers in this assay, from the lowest: compound 1; then compounds 4, 2 and 3 (each within the scatter of the next).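

In this assay, this aromatic carbon, ortho to a large group, has now carried three quite different groups. Ethoxycarbonyl brings 5 heavy atoms where iodo had 1, along with a double bond outside aromatic rings and 2 hydrogen-bond acceptors where iodo had 0, yet the result is a 1.4-fold lower number from compound 3 to compound 4 (0.14 log units; within the scatter) and, against the methyl group, a 1.2-fold lower number from compound 2 to compound 4 (0.07 log units; within the scatter). Across compounds 2, 3 and 4, then, a much larger group that can accept hydrogen bonds gives a number that cannot be told apart from those of a single iodine atom or a methyl group, although no measurement available here explains why.

From the compounds shown here alone, whether an amine or a carboxylic acid on this same aromatic carbon would also leave the number in place remains open. Compound 1 gives 9.8 nM. Also open, going by these compounds, is whether iodo or ethoxycarbonyl on the ring carbon that carries methyl in compound 1 would give a similarly low number, or whether that low number belongs to the methyl group alone.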